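This account rests on a few compounds, and the source may have more. Where it says the series, first, only, none or still open, it means among the compounds named here.

Measured so far in a functional assay on MDA-MB-231 cells (Homo sapiens), read by microscopy and transwell migration, with a stated time of 24 h; on this read-out higher numbers stand for weaker inhibition and lower numbers for stronger inhibition:
- compound 1 `Cc1sc(NC(=O)c2ccccc2)nc1-c1ccccc1`: > 25000 nM, a limit of the assay
- compound 2 `Cc1sc(NC(=O)c2ccccc2)nc1-c1ccc(F)cc1`: 9100 nM

Among the measured compounds shown here, compound 2 holds the only true number at 9100 nM. For the measured compounds named here, the single measured step, an at least 2.7-fold lower number from compound 1 to compound 2 (0.43 log units; beyond the scatter), comes with fluoro in place of hydrogen on an aromatic carbon, and it rests on (the limit of > 25000 nM in this assay, at which 1 of the 2 values shown sits).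

Compound 3 `Cc1sc(N(C)C(=O)c2ccccc2)nc1-c1ccc(F)cc1` keeps the aryl fluoride of compound 2 and changes a different place: methyl in place of hydrogen on an amide-type nitrogen. Going by the values given here, no measured step touches this nitrogen. The step of an at least 2.7-fold lower number from compound 1 to compound 2 (0.43 log units; beyond the scatter) bears on it only indirectly, showing that one small substitution can move a number beyond the scatter in this series. It gives no size or direction for the new change, so no firm shift is expected in this assay, and a wide range in either direction is kept open.

The estimated step is a 1.1-fold lower number from compound 2 to compound 3 (0.06 log units; within the scatter). For compound 3 the expected value is 8000 nM, with an estimated range of 1800 nM to 25000 nM.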

Compound 3, half-maximal inhibitory concentration: 1620 nM
For compound 3 the middle estimate is 4.9-fold (0.69 log units) above the measured one; measured number outside the range, below it.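

In this assay, a 5.6-fold lower number from compound 2 to compound 3 (0.75 log units; beyond the scatter) shows that the amide-type nitrogen is a second place in the series where one small substitution moves the number beyond the scatter, and here the substitution carries no ring, donor, acceptor or net charge. The amide hydrogen is therefore not needed for inhibition in this read-out, since compound 3 lacks it and still gives the lower number. This step also joins two true numbers and so has a definite size, whereas the earlier step rests on a limit of the assay, and nothing shown here explains why methyl on this nitrogen lowers the number.

On these data alone, whether the trend continues beyond methyl remains open, as an ethyl group, a longer chain or a chain ending in an amine or a carboxylic acid on the same nitrogen could lower the number further or reverse the change. As far as these compounds go, it is also open whether the methyl step depends on the aryl fluoride, which would take the same change on the core of compound 1 to settle.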